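Replacing a Sulfonamide Dimethylamino Group with Pyrimidinylamino

The compounds below may be only part of what the source reports. "The series", "measured", "known", "first", "only" and "open" are said of these compounds alone.

Three close analogues share one core and differ only in the group on the sulfonyl sulfur. In an assay on lysate for inhibition of 6-phosphofructo-2-kinase/fructose-2,6-bisphosphatase 3 (Homo sapiens), with stated times of 0.5 min and 45 min (on this read-out higher numbers stand for weaker inhibition and lower numbers for stronger inhibition), compound 3 `CN(C)S(=O)(=O)c1ccccc1Nc1cc(-c2ccc3ccn(C)c3c2)c2nccnc2c1` gives 7670 nM, the highest of the two numbers shown. Its nearest neighbour, compound 1 `CN1CCC(CNS(=O)(=O)c2ccccc2Nc2cc(-c3ccc4ccn(C)c4c3)c3nccnc3c2)C1`, gives 4640 nM, and the gap is a 1.7-fold higher number from compound 1 to compound 3 (0.22 log units; within the scatter). Compound 2 `CNS(=O)(=O)c1ccccc1Nc1cc(-c2ccc3ccn(C)c3c2)c2nccnc2c1` reaches only a limit of the assay, > 100000 nM, as noted in the limit of > 100000 nM in this assay, at which 1 of the 3 values shown sits.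

Compound 4 `Cn1ccc2ccc(-c3cc(Nc4ccccc4S(=O)(=O)Nc4cncnc4)cc4nccnc34)cc21` has not been measured; it differs from compound 3 by (pyrimidin-5-yl)amino in place of dimethylamino on a sulfonyl sulfur. Among the compounds with values here, two measured steps touch the same place. The step of an at least 13-fold lower number from compound 2 to compound 3 (1.11 log units; beyond the scatter) shows that a bare hydrogen on the sulfonamide nitrogen carries a heavy cost when its partner is small, whereas a 1.7-fold higher number from compound 1 to compound 3 (0.22 log units; within the scatter) shows that a hydrogen beside a larger substituent costs little. Compound 4 brings back a sulfonamide hydrogen, now paired with an aromatic ring, so the outcome sits between those two cases. The step expected is a 1.9-fold lower number from compound 3 to compound 4 (0.28 log units; within the scatter). On that basis compound 4 is expected near 4000 nM, within 700 nM to 30000 nM.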

Compound 4, half-maximal inhibitory concentration: > 100000 nM
Compound 4: only a limit was reported (the forecaster's own chance of this, stated with the estimate: 15%); at least 25-fold (1.39 log units) between middle value and limit.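

In this assay, a larger group on the sulfonamide nitrogen does not by itself make up for the sulfonamide hydrogen: pyrimidin-5-yl is larger than the methyl of compound 2, yet the change from dimethylamino gives an at least 13-fold higher number from compound 3 to compound 4 (1.11 log units; beyond the scatter). Against the (1-methylpyrrolidin-3-yl)methyl group, which also leaves a hydrogen on that nitrogen, pyrimidin-5-yl gives an at least 21-fold higher number from compound 1 to compound 4 (1.33 log units; beyond the scatter), so what matters here is the kind of group, not just its size. Compound 2 and compound 4 both end at a limit, so the step between them cannot be read: the limit of > 100000 nM in this assay, at which 2 of the 4 values shown sit.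

On these data alone, it stays open whether the aromatic ring itself or its ring nitrogens account for the result, which a plain phenyl group on the sulfonamide nitrogen would help separate. An open-chain amine such as 2-(dimethylamino)ethyl would likewise test whether the amine of compound 1 is the part that counts.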